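The compounds below may be only part of what the source reports. "The series", "measured", "known", "first", "only" and "open" are said of these compounds alone.

Of the compounds shown here, three sharing one core have numbers so far in a functional assay on KB-V1 cells (Homo sapiens) for cytotoxicity, read by MTT assay, with a stated time of 72 h; a lower number here means a stronger inhibitor, a higher number a weaker inhibitor. Compound 1 (`O=C1Nc2ccccc2/C1=N/NC(=S)Nc1cccc(Cl)c1`) gives 640 nM, compound 2 (`O=C1Nc2ccccc2/C1=N/NC(=S)Nc1c(F)cc(F)cc1F`) gives 7280 nM, and compound 3 (`CN(C)c1ccc(NC(=S)N/N=C2\C(=O)Nc3ccccc32)cc1`) gives 2320 nM. Compound 3 is therefore the middle member of the three, with a higher number than compound 1 and a lower number than compound 2. Among the measured compounds shown here, both gaps lie beyond the scatter, the one to compound 2 being the smaller. For the measured compounds named here, no two of the measured compounds differ in one place only, so no single-change step is available as a guide.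

The next compound is compound 4 (`CC(C)c1ccc(NC(=S)N/N=C2\C(=O)Nc3ccccc32)cc1`), which carries isopropyl in place of dimethylamino on an aromatic carbon. The new group stays para to a large group, and the shared core is untouched. Going by the values given here, the expectation starts from compound 3 at 2320 nM and leans towards compound 1 at 640 nM, the lowest number so far, with the uncertainty kept wide. In this assay, the expected change is a 1.9-fold lower number from compound 3 to compound 4 (0.29 log units; within the scatter), a move to a lower number of a size near the edge of the scatter. For compound 4 the estimated value is 1200 nM, with an expected range of 400 nM to 3500 nM.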

Compound 4, half-maximal inhibitory concentration: 1090 nM
Compound 4: middle estimate off by 1.1-fold (0.04 log units), on the high side; the range from low to high includes it.
By their numbers in this assay, from the lowest: compounds 1 and 4 (each within the scatter of the next); then compound 3; then compound 2.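

Among the compounds shown here, the first single-change comparison reads, in this assay, as a 2.1-fold lower number from compound 3 to compound 4 (0.33 log units; beyond the scatter), with isopropyl in place of dimethylamino on an aromatic carbon, para to a large group. Both groups count 3 heavy atoms, so this step exchanges the nitrogen and the hydrogen-bond acceptor of dimethylamino for carbon at an unchanged heavy-atom count, and the lower number in compound 4 shows that neither that nitrogen nor that acceptor is required at this position for the number to hold at this level. No measurement bearing on the origin of this modest step is at hand.

This single pair cannot separate the loss of the nitrogen from the arrival of the branched carbon group, as the two happen together in one exchange. From the compounds shown here alone, whether a tert-butyl group, a methoxy group or a carboxylic acid at the same place would extend the move to a lower number, hold it or reverse it remains open, and so does the reading of any other position on this ring.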